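Tetrazole substituent swap on a hydroxamate HDAC6 inhibitor

The compounds below may be only part of what the source reports. "The series", "measured", "known", "first", "only" and "open" are said of these compounds alone.

Compound 1 `O=C(NO)c1ccc(CNCc2nnnn2Cc2ccccc2)cc1` is a hydroxamic acid carrying a benzyl-substituted tetrazole. In an assay on isolated protein for inhibition of protein deacetylase HDAC6 (Homo sapiens), read by fluorescence, with a stated time of 90 min (on this read-out higher numbers stand for weaker inhibition and lower numbers for stronger inhibition), compound 1 gives 100 nM. Compound 2 `O=C(NO)c1ccc(CNC(c2ccccc2)c2nnnn2Cc2ccccc2)cc1` adds a phenyl to the chain carbon that joins the amine nitrogen to the tetrazole, and in this assay compound 2 gives 100 nM; the step of no change at the digits printed from compound 1 to compound 2 (within the scatter) shows that this addition lies within the scatter, so compound 1 stands level with compound 2 at the digits shown.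

Compound 3 `CC(C)(C)n1nnnc1CNCc1ccc(C(=O)NO)cc1` takes a different route: tert-butyl in place of benzyl on an aromatic nitrogen. Within the data shown here, no measured step touches this position, so the only guidance is that the one change recorded so far, no change at the digits printed from compound 1 to compound 2 (within the scatter), was flat. On that basis compound 3 is expected to stay close to compound 1, with a step of a 1.5-fold higher number from compound 1 to compound 3 (0.18 log units; within the scatter) that need not exceed the scatter. Compound 3 is estimated at 150 nM, in a range from 50 nM to 500 nM.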

Compound 3, half-maximal inhibitory concentration: 330 nM
Estimate against measurement, compound 3: 2.2-fold (0.34 log units) below, and the stated range covers the measured number.
By their numbers in this assay, from the lowest: compounds 1 and 2 (each within the scatter of the next); then compound 3.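

In this assay, tert-butyl in place of benzyl on the aromatic nitrogen gives a 3.3-fold higher number from compound 1 to compound 3 (0.52 log units; beyond the scatter), so this position, unlike the chain carbon changed in compound 2, does not tolerate every swap without a shift beyond the scatter. The step is modest, and it replaces a group of seven heavy atoms with a six-membered aromatic ring of carbon only by a group of four heavy atoms with no ring; a single swap cannot separate the loss of the ring from the change in heavy atoms or the branching. Nothing shown here accounts for the step.

The compounds shown leave open whether phenyl, phenethyl or cyclohexylmethyl on this nitrogen would stay level with compound 1 at 100 nM. On these data alone, whether adding phenyl to the chain carbon would remain flat with tert-butyl on the nitrogen also stays open.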